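The source may report more compounds than this note shows. Statements on the series, on what has been measured and on what is new or still open speak of the compounds shown alone.

Compound 1 `CC(C)c1cccc(C(C)C)c1NC(=O)CC(=O)OC(c1ccccn1)c1ccccn1`; in an assay on microsomes from intestine for inhibition of acyl-CoA:cholesterol acyltransferase (Oryctolagus cuniculus) (on this read-out higher numbers stand for weaker inhibition and lower numbers for stronger inhibition), compound 1 gives > 5000 nM, which is a limit of the assay and not a number.
Compound 2 `CCOC(=O)CC(=O)Nc1c(C(C)C)cccc1C(C)C`; in this assay compound 2 gives 1800 nM.

Compound 1 stands only at a bound, (the limit of > 5000 nM in this assay, at which 1 of the 2 values shown sits), so its true place among the numbers is open. The gap between compound 1 and compound 2 is therefore not fixed. Compound 3 `CC(C)c1cccc(C(C)C)c1NC(=O)CC(=O)OC(c1ccccc1)c1ccccn1` differs from compound 1 by phenyl in place of pyridin-2-yl on a saturated chain carbon bound to an aromatic carbon and an oxygen next to a carbonyl group. Within the data shown here, no step between measured compounds covers this change. The expected step of an at least 1.6-fold lower number from compound 1 to compound 3 (0.22 log units; that floor lies within the scatter) points toward somewhat stronger inhibition, though the scatter may well cover it. Compound 3 is expected at 3000 nM, within 800 nM to 12000 nM.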

Compound 3, half-maximal inhibitory concentration: > 5000 nM
Compound 3: only a limit was reported; the forecaster's own chance of this, stated with the estimate: 30%; at least 1.6-fold (0.22 log units) between middle value and limit.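

Compound 1 and compound 3 both stand only at a limit of this assay, not at a number, so no step between them can be read: the limit of > 5000 nM in this assay, at which 2 of the 3 values shown sit.

From the compounds shown here alone, whether phenyl in place of pyridin-2-yl shifts inhibition at all remains open.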